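The compounds below may be only part of what the source reports. "The series", "measured", "known", "first", "only" and "open" are said of these compounds alone.

Measured compounds:
compound 1 `O=C(CN1CCN(c2cc3c(cc2F)c(=O)c(C(=O)O)cn3C2CC2)CC1)Nc1ccc(C(=O)/C=C/c2ccccc2)cc1` — 6.4%
compound 2 `O=C(CN1CCN(c2cc3c(cc2F)c(=O)c(C(=O)O)cn3C2CC2)CC1)Nc1ccc(C(=O)/C=C/c2cccc([N+](=O)[O-])c2)cc1` — 11.1%

In an assay on isolated protein for inhibition of DNA topoisomerase 1 (Homo sapiens), with a stated time of 30 min, tested at 20 uM (a lower number here means a weaker effect, a higher number a stronger effect of the compound at the concentration tested), compound 1 gives 6.4% and compound 2 gives 11.1%. Going by the values given here, of the two numbers, the one for compound 2 sits at the top, but the single step between them, a number 4.7 percentage points higher from compound 1 to compound 2 (within the scatter), is within the scatter, so the two compounds are not distinguished by these data.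

Compound 3 `Cc1ccc(/C=C/C(=O)c2ccc(NC(=O)CN3CCN(c4cc5c(cc4F)c(=O)c(C(=O)O)cn5C4CC4)CC3)cc2)c(C)c1` has not yet been measured. It differs from compound 2 by 2,4-dimethylphenyl in place of 3-nitrophenyl on a double-bonded chain carbon bound to a double-bonded chain carbon. Among the compounds with values here, the only measured step that touches the same part of the molecule is a number 4.7 percentage points higher from compound 1 to compound 2 (within the scatter), where a nitro replaced hydrogen on the aromatic ring attached to the double-bonded chain; that step stayed within the scatter. Within the data shown here, there is no measured pair that bears directly on replacing 3-nitrophenyl by 2,4-dimethylphenyl, so the expectation rests on this one small step and on the low level of both numbers.

The step of a number 2.1 percentage points lower from compound 2 to compound 3 (within the scatter) is therefore expected to remain within the scatter, with no clear direction. For compound 3 the estimate is 9%, with a range from 0% to 20%.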

Compound 3, a percentage reported as inhibition, at one concentration (the size of the read-out at that concentration, not a potency): 11%
Estimate against measurement, compound 3: 2 percentage points below; the measured number falls inside the stated range.
By their numbers in this assay, from the lowest: compounds 1, 3 and 2 (each within the scatter of the next).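

Notes on the aryl group on a double-bonded chain carbon bound to a double-bonded chain carbon: in this assay, replacing 3-nitrophenyl with 2,4-dimethylphenyl gives a number 0.1 percentage points lower from compound 2 to compound 3 (within the scatter), while replacing phenyl with the same group gives a number 4.6 percentage points higher from compound 1 to compound 3 (within the scatter), so neither step separates the compounds. The earlier pair covered only a nitro in place of hydrogen, whereas this series now also includes a carbon-only group with two methyl groups on the ring, and phenyl, 3-nitrophenyl and 2,4-dimethylphenyl cannot be told apart by these numbers. No independent measurement is available to interpret this absence of separation.

Open, on these data alone, is whether any group at this position can move the number in this assay beyond the scatter, for example an amine or a carboxylic acid on the ring, or a pyridine or cyclohexyl ring in place of the aromatic carbon ring. Also open, as far as these compounds go, is whether a change elsewhere, such as a saturated two-carbon chain in place of the double-bonded chain or a longer chain between the piperazine and the amide, would separate compounds that this aryl position does not.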